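The compounds below may be only part of what the source reports. "The series", "measured", "known", "first", "only" and "open" are said of these compounds alone.

Working notes on the series

The shared core is seen in compound 1 `Cc1ccc(C2CN(C)Cc3c(N)cccc32)cc1` and in compound 2 `CCCNC(=O)Nc1cccc2c1CN(C)CC2c1ccccc1`, which differ at more than one place, so only their two values are set side by side. In a functional assay on the whole organism for inhibition, with Mus musculus as the target (a higher number here means that more compound is needed for the effect, a lower number that less compound is needed), compound 1 gives 1.6 mg/kg. For compound 2 the this assay result is only a limit, > 80 mg/kg, and no number stands for it. For the measured compounds named here, this is the limit of > 80 mg/kg in this assay, at which 1 of the 2 values shown sits, so no measured step between the two compounds can be sized.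

Compound 3 `CC(C)NCCC(=O)Nc1cccc2c1CN(C)CC2c1ccccc1` keeps the core of compound 2 and alters the group on the carbonyl carbon: 2-(isopropylamino)ethyl in place of propylamino on a carbonyl carbon. Since compound 2 sits at a limit, the size of the step in this assay cannot be read from measured values; the expectation is a step of an at least 1.6-fold lower number from compound 2 to compound 3 (0.20 log units; that floor lies within the scatter) that stays modest, within or near the scatter, with no clear direction. For compound 3 the expected dose in this assay is 50 mg/kg. The expected range for compound 3 runs from 10 mg/kg to 200 mg/kg, and it is likely that compound 3 again returns only a limit.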

Compound 3, dose for half-maximal effect: 150 mg/kg
Compound 3: the middle estimate sits 3.0-fold (0.48 log units) below what was measured, within the range that was stated.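

The step from compound 2 to compound 3 cannot be read in this assay, because compound 2 stands at a limit and not at a number: the limit of > 80 mg/kg in this assay, at which 1 of the 3 values shown sits.

The compounds shown leave open whether 2-(isopropylamino)ethyl in place of propylamino on a carbonyl carbon changes the dose needed in this assay at all, and in which direction.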